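Cyanoguanidines: swapping the alkyl group on the imine nitrogen

This account rests on a few compounds, and the source may have more. Where it says the series, first, only, none or still open, it means among the compounds named here.

Compound 1 `N#CN/C(=N\C1CCCC1)Nc1cc(Cl)cc(Cl)c1` is the starting point of this step. In a functional assay on Beta-TC3 cells (Rattus norvegicus) with Beta-TC3 (Mus musculus) as the target, using a membrane potential dye (on this read-out higher numbers stand for weaker inhibition and lower numbers for stronger inhibition), compound 1 gives 12000 nM, which at the digits reported is level with compound 2 `C[C@H](/N=C(\NC#N)Nc1cc(C(F)(F)F)cc(C(F)(F)F)c1)C(C)(C)C`, whose result in this assay is 12000 nM; together these two stand as the highest numbers among the three measured compounds. Compound 3 `CC(C)C(C)/N=C(\NC#N)Nc1cc(C(F)(F)F)cc(C(F)(F)F)c1` sits a little lower, giving 5500 nM in this assay.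

Compound 4 `CCC(C)(C)/N=C(\NC#N)Nc1cc(Cl)cc(Cl)c1` differs from compound 1 in one place: 1,1-dimethylpropyl in place of cyclopentyl on a double-bonded nitrogen. Going by the values given here, the only measured step that bears on this kind of change is the one on a different core, where a change of the alkyl group on the same double-bonded nitrogen produced a 2.2-fold lower number from compound 2 to compound 3 (0.34 log units; beyond the scatter). That step was modest and only just beyond the scatter, and it involved different groups than the present exchange, so it offers limited guidance for the direction of the change from compound 1 to compound 4.

On that basis compound 4 is expected to remain close to compound 1, with a 1.3-fold lower number from compound 1 to compound 4 (0.12 log units; within the scatter) as the estimated shift, which lies within the scatter. The estimate for compound 4 in this assay is therefore 9000 nM, with a plausible range from 3500 nM to 25000 nM.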

Compound 4, half-maximal inhibitory concentration: 24000 nM
Compound 4: the middle estimate sits 2.7-fold (0.43 log units) below what was measured; the measured number falls inside the stated range.
By their numbers in this assay, from the lowest: compound 3; then compounds 1, 2 and 4 (each within the scatter of the next).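

In this assay, the exchange of cyclopentyl for 1,1-dimethylpropyl on the double-bonded nitrogen gives a 2.0-fold higher number from compound 1 to compound 4 (0.30 log units; within the scatter), so on the core of compound 1 the ring can be opened into a branched group of the same heavy-atom count without the result leaving the scatter. This is the first one-place change shown on that core, and it differs from the only earlier step, a 2.2-fold lower number from compound 2 to compound 3 (0.34 log units; beyond the scatter), which also swapped one alkyl group for another on this nitrogen but is printed as beyond the scatter. Nothing available offers an explanation for either step, so the two can be set side by side only as numbers.

Going by these compounds, what an amine or a hydroxyl on the alkyl group, or a much shorter chain such as ethyl, would do at this nitrogen stays open. Also open is whether a given alkyl group behaves alike on both cores, since no pair shown carries the same alkyl group with chloro substituents on one partner and trifluoromethyl groups on the other.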